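Trifluoromethoxy for Trifluoromethyl on a Shared Urea Scaffold

The compounds below may be only part of what the source reports. "The series", "measured", "known", "first", "only" and "open" are said of these compounds alone.

Compound 3 `O=C(Nc1ccc(C(F)(F)F)cc1)N1CCN(c2ccc(-c3ccccc3)nn2)CC1` was tested in an assay on HEK293 cells for inhibition of transient receptor potential cation channel subfamily V member 1 (Homo sapiens), read by FLIPR; on this read-out lower numbers stand for stronger inhibition and higher numbers for weaker inhibition. In this assay compound 3 gives > 10000 nM, which is a limit of the assay rather than a number. Compound 1 `Cc1ccc(N2CCN(C(=O)Nc3ccc(OC(F)(F)F)cc3)CC2)nn1` in this assay gives > 10000 nM, also a limit. Compound 2 `CC(C)c1ccc(NC(=O)N2CCN(c3ccc(-c4ccccc4)nn3)CC2)cc1` in this assay gives > 10000 nM, again a limit. Within the data shown here, compound 3 thus stands at the limit of > 10000 nM in this assay, at which 3 of the 3 values shown sit, with no compound in the set yielding a readable number. Among the measured compounds shown here, the only measured step that changes a single place, a step that the two limits leave unreadable from compound 2 to compound 3, cannot be sized because both of its ends are limits.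

Compound 4 `O=C(Nc1ccc(OC(F)(F)F)cc1)N1CCN(c2ccc(-c3ccccc3)nn2)CC1` differs from compound 3 by trifluoromethoxy in place of trifluoromethyl on an aromatic carbon. For the measured compounds named here, no measured step speaks directly to this exchange, and the one recorded step offers no size to carry over. Compound 1 carries the same trifluoromethoxy group on a related core and is itself only a limit. Compound 4 is therefore expected to show a step that the limit leaves unreadable from compound 3 to compound 4, that is, no change that can be read. The estimate for compound 4 in this assay is 20000 nM, within 5000 nM to 100000 nM, and most likely reported again only as a limit.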

Compound 4, half-maximal inhibitory concentration: > 10000 nM
Compound 4: only a limit was reported; the forecaster's own chance of this, stated with the estimate: 80%; the middle value lies beyond the limit too.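

Compound 4 gives no readable step from compound 1, compound 2 or compound 3 in this assay, as all of these results are limits rather than numbers: the limit of > 10000 nM in this assay, at which 4 of the 4 values shown sit. Still open, going by these compounds, is whether trifluoromethoxy in place of trifluoromethyl changes inhibition at all, and whether any compound of this kind reaches a readable number.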